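The source may hold more compounds than are shown below. What is called first, only, known or untested is meant among the compounds shown, and "the series" means these compounds.

Working notes on the series in an assay on CHO-K1 cells for inhibition of 11-beta-hydroxysteroid dehydrogenase type 2 (Mus musculus), read by scintillation proximity assay; a lower number here means a stronger inhibitor, a higher number a weaker inhibitor. Compound 1 `CCOCC12CCC(c3nnc(-c4ccccc4C(F)(F)F)n3C)(CC1)CC2` carries an ethoxy group on a saturated chain carbon bound to a saturated ring carbon. In this assay compound 1 gives > 4000 nM, which is a limit of the assay and not a number. Compound 2 `CC(C)S(=O)(=O)CCC12CCC(c3nnc(-c4ccccc4C(F)(F)F)n3C)(CC1)CC2` carries (isopropylsulfonyl)methyl in place of ethoxy, and compound 3 `Cn1c(-c2ccccc2C(F)(F)F)nnc1C12CCC(CCS(C)(=O)=O)(CC1)CC2` carries (methylsulfonyl)methyl there. In this assay compound 2 gives > 4000 nM, a limit. In this assay compound 3 gives > 4000 nM, again a limit. The steps are accordingly a step that the two limits leave unreadable from compound 1 to compound 2, a step that the two limits leave unreadable from compound 1 to compound 3 and a step that the two limits leave unreadable from compound 2 to compound 3; none of them can be sized because of the limit of > 4000 nM in this assay, at which 3 of the 3 values shown sit. Compound 3 thus stands at the same limit as the two others, with no number to rank it.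

Compound 4 `Cn1c(-c2ccccc2C(F)(F)F)nnc1C12CCC(CNS(C)(=O)=O)(CC1)CC2` is the next member: methanesulfonamido in place of (methylsulfonyl)methyl on a saturated chain carbon bound to a saturated ring carbon. The measured steps that touch the same saturated chain carbon bound to a saturated ring carbon, from compound 1 to compound 2 and from compound 1 to compound 3, are unreadable, and the exchange of methyl for isopropyl on the sulfonyl sulfur is likewise unreadable. Among the compounds with values here, no measured step therefore gives a direction or a size for the change to methanesulfonamido; the one consistent observation is that every variant on this chain so far has stayed at the limit. For compound 4 the expected step is a step that the limit leaves unreadable from compound 3 to compound 4, none beyond the scatter, with the number itself uncertain. Compound 4 is estimated at 6000 nM, ranging from 2000 nM to 30000 nM, and most likely reported as a limit once more.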

Compound 4, half-maximal inhibitory concentration: > 4000 nM
Compound 4: a limit, no number (the forecaster's own chance of this, stated with the estimate: 75%); the middle value is on the limit's open side.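

In this assay compound 4 gives > 4000 nM, again a limit and not a number. Within the data shown here, no step to compound 4 from compound 1, compound 2 or compound 3 can be read: the limit of > 4000 nM in this assay, at which 4 of the 4 values shown sit. The compounds shown leave open how methanesulfonamido ranks against ethoxy, (isopropylsulfonyl)methyl and (methylsulfonyl)methyl, and whether any group at this place gives a measurable value.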